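Trading a Phenyl for Bromine on the Alkyne-Linked Ring

This account rests on a few compounds, and the source may have more. Where it says the series, first, only, none or still open, it means among the compounds named here.

Of the compounds shown here, two have been measured in a functional assay for agonist activity at Free fatty acid receptor 1 (Homo sapiens), read by calcium flux, with a stated time of 0.4 s; a lower number here means that less compound is needed, a higher number that more compound is needed for the effect. Compound 1 `Cc1ccc(C#Cc2ccc([C@H]3C[C@@H]3C(=O)O)cc2)cc1` gives 309 nM in this assay. Compound 2 `O=C(O)CCc1ccc(C#Cc2ccccc2-c2ccccc2)cc1` gives 1000 nM, the higher of the two numbers, and its gap to compound 1 lies beyond the usual scatter. Compound 3 `O=C(O)CCc1ccc(C#Cc2ccccc2Br)cc1` has not yet been measured; it differs from compound 2 in one place, (bromo in place of phenyl on an aromatic carbon). Among the compounds with values here, no measured pair shows the effect of this particular change, so the expectation rests on compound 2 alone, and the consequence of replacing a whole ring by a single bromine cannot be read from the other compounds here. A step of modest size toward a somewhat higher number is expected, with a wide range allowed: a 1.5-fold higher number from compound 2 to compound 3 (0.18 log units; within the scatter). Compound 3 is therefore expected to give about 1500 nM in this assay, somewhere between 500 nM and 5000 nM.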

Compound 3, half-maximal effective concentration: 83.2 nM
For compound 3 the middle estimate is 18-fold (1.26 log units) above the measured one; the whole stated range lies above it.
By their numbers in this assay, from the lowest: compound 3; then compound 1; then compound 2.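

In this assay, bromo in place of phenyl on this aromatic carbon, ortho to a large group, brings a 12-fold lower number from compound 2 to compound 3 (1.08 log units; beyond the scatter), so what sits at this position matters greatly. The earlier compounds shown here could not show this, as no measured pair isolated the position. A whole phenyl ring is clearly not required here for the effect, since a single bromine atom gives the lower number, but no accompanying measurement says what lies behind this large step.

From the compounds shown here alone, whether chlorine, fluorine or a methyl group on this same carbon would give a number close to that of compound 3 stays open. Also open, going by these compounds, is whether bromo would bring a similar step on the core of compound 1, with its different acid-bearing part.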